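Carbamate and thiocarbamate variation on a piperidine series

The source may hold more compounds than are shown below. What is called first, only, known or untested is meant among the compounds shown, and "the series" means these compounds.

Measured so far:
Compound 1 `Cc1nc(S(C)(=O)=O)ccc1Oc1ncnc(OC2CCN(C(=O)OC(C)(C)C#N)CC2)c1F` — 97%
Compound 2 `Cc1nc(S(C)(=O)=O)ccc1Oc1ncnc(OC2CCN(C(=O)O[C@H](C)C(F)(F)F)CC2)c1F` — 85%
Compound 3 `CCC1(OC(=O)N2CCC(Oc3ncnc(Oc4ccc(S(C)(=O)=O)nc4C)c3F)CC2)CC1` — 83%

In a functional assay on isolated protein for inhibition of Glucose-dependent insulinotropic receptor (Rattus norvegicus), read by HTRF and cAMP accumulation (a lower number here means a smaller maximal response, a higher number a larger maximal response), compound 3 gives the lowest of the three numbers: against compound 2 the gap is within the scatter (a number 2 percentage points lower from compound 2 to compound 3 (within the scatter)), against compound 1 it is beyond it (a number 14 percentage points lower from compound 1 to compound 3 (beyond the scatter)). Compound 4 `Cc1nc(S(C)(=O)=O)ccc1Oc1ncnc(OC2CCN(C(=S)OC3(C)CC3)CC2)c1F` differs from compound 3 on the amine nitrogen in the ring: a group of 7 heavy atoms (5 carbon, 1 oxygen, 1 sulfur; one three-membered non-aromatic ring of carbon only) in place of a group of 8 heavy atoms (6 carbon, 2 oxygen; one three-membered non-aromatic ring of carbon only), on an amine nitrogen in a ring. The three-membered non-aromatic ring of carbon only stays. Of the measured steps, only a number 12 percentage points lower from compound 1 to compound 2 (beyond the scatter) and a number 14 percentage points lower from compound 1 to compound 3 (beyond the scatter) change the same position, and both are modest; a number 2 percentage points lower from compound 2 to compound 3 (within the scatter) is flat. Among the measured compounds shown here, no measured step alters the carbonyl itself. The step of a number 3 percentage points lower from compound 3 to compound 4 (within the scatter) is therefore expected to stay within the scatter. Compound 4 is estimated at 80%, between 65% and 95%.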

Compound 4, largest response reached (reported as efficacy), in percent of the reference or control that the assay uses: 49%
Beside the measured number, compound 4's estimate is 31 percentage points above it; measured number outside the range, below it.
By their numbers in this assay, from the lowest: compound 4; then compounds 3 and 2 (each within the scatter of the next); then compound 1.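

In this assay, the group on the amine nitrogen in a ring matters far more than the carbamate steps suggested: a number 34 percentage points lower from compound 3 to compound 4 (beyond the scatter) and a number 36 percentage points lower from compound 2 to compound 4 (beyond the scatter) and a number 48 percentage points lower from compound 1 to compound 4 (beyond the scatter) are all large. Sulfur enters here together with a changed cyclopropyl substituent, so these steps belong to the combined change only. Nothing at hand accounts for the drop.

Still open, as far as these compounds go, is whether sulfur or the substituent carries the step, which 1-methylcyclopropyl on the plain carbonyl would separate. A thiocarbonyl bearing 1-cyano-1-methylethyl would test whether the drop carries over.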